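A few compounds are considered here, and "the series" means these few. Any claim that something is new, unique, unknown or untested is made for them only; others in the source may bear on it.

Compound 1 `COc1ccc(/C=C2\S/C(=N\c3ccccc3)N(Cc3ccco3)C2=O)cc1OC`: > 250000 nM
Compound 2 `O=C1/C(=C/c2cccc([N+](=O)[O-])c2)S/C(=N\c2ccccc2)N1Cc1ccco1`: "not determined" (no result reported)
Compound 3 `O=C1/C(=C/c2ccc(O)cc2)S/C(=N\c2ccccc2)N1Cc1ccco1`: > 250000 nM

In a toxicity assay on CHO cells (Cricetulus griseus) for cytotoxicity, read by MTT assay, with a stated time of 72 h (on this read-out lower numbers stand for stronger inhibition and higher numbers for weaker inhibition), compound 1 gives > 250000 nM, which is a limit of the assay and not a number. Compound 3 gives > 250000 nM, which is also a limit. Compound 2 has the entry "not determined" (no result reported), so it offers no comparison. The whole picture is therefore thin: the limit of > 250000 nM in this assay, at which 2 of the 3 values shown sit.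

Compound 4 `Cc1ccc(/C=C2\S/C(=N\c3ccccc3)N(Cc3ccco3)C2=O)cc1` keeps the core of compound 1 and changes one group: 4-methylphenyl in place of 3,4-dimethoxyphenyl on a double-bonded chain carbon bound to a double-bonded ring carbon. In words, 4-methylphenyl stands in place of 3,4-dimethoxyphenyl on a double-bonded chain carbon bound to a double-bonded ring carbon.

Within the data shown here, only one measured step touches this place, a step that the two limits leave unreadable from compound 1 to compound 3, where 4-hydroxyphenyl replaces the same 3,4-dimethoxyphenyl. That step has no size to carry over, but neither of its two compounds gave a number in this assay. Compound 4 is thus expected to behave the same way, most likely reaching the limit again. The expected result is a number no higher from compound 1 to compound 4 (the limit leaves the size open), an estimated step with no direction and no size beyond the usual scatter. For compound 4 the estimated value is 250000 nM, with an expected range from 100000 nM to 500000 nM.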

Compound 4, half-maximal inhibitory concentration: 185000 nM
Compound 4: middle estimate off by 1.4-fold (0.13 log units), on the high side, and the stated range covers the measured number.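

In this assay compound 4 gives 185000 nM, the first true number among these compounds for a change on a double-bonded chain carbon bound to a double-bonded ring carbon, so this place can hold a group that brings the reading inside the range of the assay. Replacing 3,4-dimethoxyphenyl with 4-methylphenyl gives an at least 1.3-fold lower number from compound 1 to compound 4 (0.13 log units; that floor lies within the scatter), and the simpler exchange of hydroxy for methyl on an aromatic carbon gives an at least 1.3-fold lower number from compound 3 to compound 4 (0.13 log units; that floor lies within the scatter). Each of these sizes is only a floor, not a full measure of the step, because one compound in each pair stands at a limit of the assay rather than at a number: the limit of > 250000 nM in this assay, at which 2 of the 4 values shown sit.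

As far as these compounds go, how far the true values of compound 1 and compound 3 lie from that of compound 4 remains open, so the real size of both steps is unknown. Also open, from the compounds shown here alone, is whether a carboxylic acid or an amine on the aromatic ring at this place would move the number further, in either direction, from where compound 4 stands.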